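Methylamino to Propylamino in a Pair of Aminophenyl Compounds

This account rests on a few compounds, and the source may have more. Where it says the series, first, only, none or still open, it means among the compounds named here.

Compound 1 `CCCCC(=O)NCCC(=O)c1cc(OC)ccc1N` gives 14.1% in an assay for inhibition of Nitric oxide synthase, inducible (Homo sapiens), read by scintillation counting, with a stated time of 30 min, tested at 1 mM; a higher number here means more inhibition at the concentration tested (going by the name of the read-out), a lower number less inhibition.
Compound 2 `CNC(=S)NCCC(O)c1ccccc1N` gives 20.7% in this assay.

Of the compounds shown here, two have been measured so far. Compound 1 is an amide carrying a methoxy group on its aromatic ring; compound 2 carries a thiocarbonyl-bearing chain ending in a secondary alcohol. In this assay, among the measured compounds shown here, the two numbers sit within the usual scatter of each other, so neither compound can be set apart from the other on the basis of what has been measured, and no step between them is counted.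

Compound 3 `CCCNC(=S)NCCC(O)c1ccccc1N` is the next compound in the series and has not yet been measured. It differs from compound 2 in a single place: ethyl in place of hydrogen on a saturated chain carbon bound to an amide-type nitrogen. For the measured compounds named here, no counted step between measured compounds speaks to such a change, so there is nothing in the data that would argue for a shift in either direction. Compound 3 is therefore expected to lie close to compound 2, with the step of a number 1.3 percentage points higher from compound 2 to compound 3 (within the scatter) estimated as nothing beyond the scatter. Compound 3 is estimated at 22%, within a range from 8% to 36%.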

Compound 3, a percentage reported as inhibition, at one concentration (the size of the read-out at that concentration, not a potency): 31.1%
The estimate for compound 3 lay 9.1 percentage points below the measured number; measured number inside the range.
By their numbers in this assay, from the lowest: compounds 1 and 2 (each within the scatter of the next); then compound 3.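

In this assay, among the compounds shown here, methylamino to propylamino gives a number 10.4 percentage points higher from compound 2 to compound 3 (beyond the scatter), a modest change and the only counted step so far. Compound 1 and compound 2 had offered no single-place comparison, whereas this pair shows that the position, a saturated chain carbon bound to an amide-type nitrogen, does not leave the number unchanged when ethyl replaces hydrogen, an addition of 2 heavy atoms, both carbon, with 0 hydrogen-bond donors and 0 hydrogen-bond acceptors. No measurement at hand accounts for the step.

One step cannot tell whether the number would keep moving with a longer chain such as butyl or pentyl, or whether a branched isopropyl, a cyclohexyl or a phenyl group in the same place would give a similar result. The compounds shown also leave open whether a terminal amine or carboxylic acid on the propyl chain would preserve the step, and whether the same change would carry over to the core of compound 1, with its carbonyl and methoxy group.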